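This account rests on a few compounds, and the source may have more. Where it says the series, first, only, none or still open, it means among the compounds named here.

In a functional assay on SK-OV-3 cells (Homo sapiens) for inhibition, read by sulforhodamine B assay, with a stated time of 48 h (a lower number here means that less compound is tolerated, a higher number that more compound is tolerated), compound 1 `COc1cc(-c2nn(-c3cccc(NC(=O)Nc4cc(C(F)(F)F)cc(C(F)(F)F)c4)c3)cc2-c2ccncc2)ccc1Cl` gives 15400 nM as a measured number. Compound 2 `COc1cc(-c2nn(-c3cccc(NC(=O)c4cccc(C(F)(F)F)c4)c3)cc2-c2ccncc2)ccc1Cl` gives > 50000 nM in this assay and this is a limit, not a number. Compound 2 thus stands at the limit of > 50000 nM in this assay, at which 1 of the 2 values shown sits, and has no exact value of its own.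

Compared with compound 2, compound 3 `COc1cc(-c2nn(-c3cccc(NC(=O)c4ccccc4)c3)cc2-c2ccncc2)ccc1Cl` has hydrogen in place of trifluoromethyl on an aromatic carbon, meta to a large group, so 3-(trifluoromethyl)phenyl becomes phenyl (hydrogen in place of trifluoromethyl on an aromatic carbon). Among the measured compounds shown here, no measured pair shows this change on its own. The expectation therefore rests on compound 2 with its limit of > 50000 nM and foresees no step beyond the scatter in this assay and no clear direction. The expected size of the change, a number no higher from compound 2 to compound 3 (the limit leaves the size open), is small. The estimate for compound 3 is 50000 nM with an expected range of 20000 nM to 100000 nM and a limit rather than a number may well come back.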

Compound 3, concentration lethal to 50% of the cells: > 100000 nM
Compound 3 ended at the assay's limit (the forecaster's own chance of this, stated with the estimate: 70%); middle value at least 2.0-fold (0.30 log units) from the limit.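

In this assay, among the compounds shown here, compound 2 and compound 3 both carry limits, not numbers, and no step between them can be read. The compounds shown leave open how far hydrogen in place of trifluoromethyl on an aromatic carbon shifts the tolerated concentration.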